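The source may hold more compounds than are shown below. What is called first, only, known or untested is meant among the compounds shown, and "the series" means these compounds.

Measured compounds:
Compound 1 `COc1ccc(F)cc1CNCCCNc1ccnc2cc(CCc3ccccc3)ccc12`: 9.47
Compound 2 `c1ccc(CCc2ccc3c(NCCCNCc4ccco4)ccnc3c2)cc1`: 9.47
Compound 3 `CC(C)(C)c1ccc(-c2ccc3c(NCCCNCc4ccco4)ccnc3c2)cc1`: 9.47

The read-out throughout is a physicochemical assay for acid dissociation. In this assay compound 1 gives 9.47, level with compound 2 and compound 3 at the digits shown. Neither of the two measured steps moves the value: no change at the digits printed from compound 1 to compound 2 (within the scatter) and no change at the digits printed from compound 2 to compound 3 (within the scatter).

Compound 4 `COc1ccc(F)cc1CNCCCNc1ccnc2cc(-c3ccc(C(F)(F)F)cc3)ccc12` has not yet been measured. It differs from compound 1 in one place, (4-(trifluoromethyl)phenyl in place of phenethyl on an aromatic carbon). Among the compounds with values here, the step that bears on it is the one from compound 2 to compound 3, which also exchanges phenethyl for a substituted phenyl group on the same aromatic carbon of the core, and that step was flat within the scatter. Within the data shown here, the step from compound 1 to compound 2, on the saturated chain carbon bound to an amine nitrogen, was likewise flat, so the three compounds measured so far give no sign that changes at either position move this assay.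

On that basis compound 4 is expected to sit with the others: the expected step is no change at the digits printed from compound 1 to compound 4 (within the scatter), that is, none beyond the scatter. The estimate for compound 4 is 9.47, with a range from 9.17 to 9.77.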

Compound 4, acid dissociation constant: 9.47
Compound 4: the middle estimate sits on the measured number at the digits printed, within the range that was stated.
By their numbers in this assay, from the lowest: compounds 1, 2, 3 and 4 (each within the scatter of the next).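

In this assay, 4-(trifluoromethyl)phenyl in place of phenethyl on this aromatic carbon gives no change at the digits printed from compound 1 to compound 4 (within the scatter), and the group entering here brings fluorine into the series at this position for the first time among the compounds shown. The earlier step at the same carbon, no change at the digits printed from compound 2 to compound 3 (within the scatter), was read with furan-2-yl on the saturated chain carbon, whereas the new step is read with 5-fluoro-2-methoxyphenyl there, so the flat reading for a phenethyl-to-substituted-phenyl exchange now holds with both of these groups in the compounds shown. No supporting measurement is available to say why this position leaves the number level.

The compounds shown give no reading for a carboxylic acid or an aliphatic amine on the phenyl ring at this aromatic carbon, so it remains open whether the level reading extends to such groups. They also all share one chain carrying the amine nitrogen, which leaves the outcome of a longer chain there open as well.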